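The compounds below may be only part of what the source reports. "The series", "measured", "known", "first", "only" and "open" are said of these compounds alone.

Working notes on the series. Compound 1 `C/C(=C\c1ccc(-c2ccc(F)cc2)o1)C(N)=O` carries the amide-bearing side chain on its core; in a functional assay on HO8910 cells (Homo sapiens) for cytotoxicity, read by CCK-8 assay, with a stated time of 24 h (a higher number here means a weaker inhibitor, a lower number a stronger inhibitor), compound 1 gives 990 nM. Compound 2 `C/C(=C\c1cc(-c2ccc(S(C)(=O)=O)cc2)cs1)C(N)=O` is the other measured member, built on a different core and bearing a methylsulfonyl on the outer ring. In this assay compound 2 gives only > 50000 nM, which is a limit of the assay rather than a number, as recorded in the limit of > 50000 nM in this assay, at which 1 of the 2 values shown sits. For the measured compounds named here, compound 2 thus stands at the unresolved end of the two values shown; the two numbers show only that compound 1 is active where compound 2 is not resolved, and nothing more can be read between them.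

Compound 3 `C=Cc1ccc(-c2csc(/C=C(\C)C(N)=O)c2)cc1` is not yet measured. It differs from compound 2 by vinyl in place of methylsulfonyl on an aromatic carbon. Going by the values given here, no measured step of this kind exists in the set, so the size of the change in this assay cannot be read from the data. The expected step of an at least 2.5-fold lower number from compound 2 to compound 3 (0.39 log units; beyond the scatter) is modest and not clearly beyond the scatter. Compound 3 is estimated at 20000 nM, within 3000 nM to 100000 nM, with a real chance that only a limit is reported again.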

Compound 3, half-maximal inhibitory concentration: > 50000 nM
Compound 3: only a limit was reported; the forecaster's own chance of this, stated with the estimate: 50%; middle value at least 2.5-fold (0.39 log units) from the limit.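

Compound 2 and compound 3 both stop at a limit of the assay in this assay, so no size can be read for the step between them: the limit of > 50000 nM in this assay, at which 2 of the 3 values shown sit.

The compounds shown leave open whether vinyl in place of methylsulfonyl on an aromatic carbon changes the number in this assay at all, and in which direction.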